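A few compounds are considered here, and "the series" means these few. Any claim that something is new, unique, unknown or untested is made for them only; others in the source may bear on it.

Compound 1 `CCOC(=O)C1=Cc2ccccc2OC1(OCc1cn(CC(=O)NC2CCCCC2)nn1)C(F)(F)F` — 9900 nM
Compound 2 `CCOC(=O)C1=Cc2ccccc2OC1(OCc1cn(-c2cccc(C(F)(F)F)c2)nn1)C(F)(F)F` — a limit, > 150000 nM

In a functional assay on A549 cells (Homo sapiens) for inhibition, read by MTT assay, with a stated time of 24 h (a higher number here means a weaker inhibitor, a lower number a stronger inhibitor), compound 1 gives 9900 nM. For compound 2 the figure of > 150000 nM is a limit of the assay, not a number. Compound 2 therefore sits at the limit of > 150000 nM in this assay, at which 1 of the 2 values shown sits, the weak end of what was measured. Compound 3 `CCOC(=O)C1=Cc2ccccc2OC1(OCc1cn(CC(=O)Nc2cccc(F)c2)nn1)C(F)(F)F` is not yet measured. From compound 2 to compound 3, (((3-fluorophenyl)carbamoyl)methyl in place of 3-(trifluoromethyl)phenyl on an aromatic nitrogen). For the measured compounds named here, the one measured step bears on this in reverse: an at least 15-fold higher number from compound 1 to compound 2 (1.18 log units; beyond the scatter), a large loss. Putting a ((3-fluorophenyl)carbamoyl)methyl group back on that nitrogen is expected to recover much of it, an at least 10-fold lower number from compound 2 to compound 3 (1.00 log units; beyond the scatter). Compound 3 is estimated at 15000 nM, probably between 5000 nM and 60000 nM.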

Compound 3, half-maximal inhibitory concentration: > 150000 nM
Compound 3 ended at the assay's limit; the forecaster's own chance of this, stated with the estimate: 20%; at least 10-fold (1.00 log units) between middle value and limit.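

With 3-fluorophenyl in place of cyclohexyl on the amide-type nitrogen, this assay shows an at least 15-fold higher number from compound 1 to compound 3 (1.18 log units; beyond the scatter). Keeping the amide chain on the aromatic nitrogen is therefore not enough on its own, and in this pair the group at the end of that chain decides the result. The step between compound 2 and compound 3 cannot be read, as both values are limits of the assay: the limit of > 150000 nM in this assay, at which 2 of the 3 values shown sit.

On these data alone, it remains open whether cyclopentyl, a butyl chain or benzyl on the amide-type nitrogen would keep the level of compound 1 at 9900 nM. As far as these compounds go, whether plain phenyl, without the fluorine, would behave like the 3-fluorophenyl group also stays open.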